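Changing the aryl group on a thiourea-bearing core

A few compounds are considered here, and "the series" means these few. Any claim that something is new, unique, unknown or untested is made for them only; others in the source may bear on it.

Measured compounds:
- compound 1, `NC(=O)c1c(NC(=O)c2ccccc2Cl)sc2c1CCNC2`: 18600 nM
- compound 2, `NC(=O)c1c(NC(=O)c2ccccc2Cl)sc2c1CCN(Cc1cc(Cl)cc(Cl)c1)C2`: 15800 nM
- compound 3, `NC(=O)c1c(NC(=O)c2ccccc2Cl)sc2c1CCN(C(=S)Nc1ccccc1F)C2`: 4970 nM

These three compounds share one core and differ only in what sits on an amine nitrogen in a ring. In a functional assay on HL-60 cells (Homo sapiens) for antiproliferative activity, with a stated time of 24 h (a lower number here means a stronger inhibitor, a higher number a weaker inhibitor), compound 3 gives the lowest of the three numbers. The step of a 3.7-fold lower number from compound 1 to compound 3 (0.57 log units; beyond the scatter) and the step of a 3.2-fold lower number from compound 2 to compound 3 (0.50 log units; beyond the scatter) both go beyond the scatter, so compound 3 is the strongest inhibitor among them, while the step of a 1.2-fold lower number from compound 1 to compound 2 (0.07 log units; within the scatter) stays within the scatter.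

Compound 4, `COc1ccc(NC(=S)N2CCc3c(sc(NC(=O)c4ccccc4Cl)c3C(N)=O)C2)cc1`, keeps the thiourea of compound 3 and alters only the aromatic ring on it: 4-methoxyphenyl in place of 2-fluorophenyl on an amide-type nitrogen. For the measured compounds named here, no measured step changes this ring, so nothing shows directly how large such a change can be. The measured steps only show that the whole group on the ring nitrogen moves the number by a modest amount at most. A change at the far end of that group, keeping the thiourea itself, is therefore expected to move the number little, in either direction. Compound 4 is expected to give about 5500 nM in this assay, between 2000 nM and 15000 nM, an estimated step of a 1.1-fold higher number from compound 3 to compound 4 (0.04 log units; within the scatter).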

Compound 4, half-maximal inhibitory concentration: 15700 nM
Compound 4: middle estimate off by 2.9-fold (0.46 log units), on the low side; the measured number lies above the stated range.
By their numbers in this assay, from the lowest: compound 3; then compounds 4, 2 and 1 (each within the scatter of the next).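

In this assay, the ring at the far end of the thiourea turns out to matter: 4-methoxyphenyl in place of 2-fluorophenyl on an amide-type nitrogen gives a step beyond the scatter (a 3.2-fold higher number from compound 3 to compound 4 (0.50 log units; beyond the scatter)), although the thiourea itself is unchanged. The thiourea alone is therefore not enough for the lower number, as both remaining comparisons stay within the scatter (a 1.0-fold lower number from compound 2 to compound 4 (0.00 log units; within the scatter); a 1.2-fold lower number from compound 1 to compound 4 (0.07 log units; within the scatter)), and only compound 3 stands apart as the strongest inhibitor of the set. Nothing measured here explains why these two rings behave differently.

With only these two rings on the thiourea, the change cannot be split into its two parts, the swap of fluorine for methoxy and the shift in where that group sits, so 4-fluorophenyl and 2-methoxyphenyl would be the telling partners. As far as these compounds go, it also remains open how a plain phenyl ring, or a phenyl ring carrying an amine or a carboxylic acid, would fare, and whether a urea, with oxygen in place of the thiocarbonyl sulfur, would keep the number of compound 3.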